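Removing a methyl from the chain of compound 2

The source may hold more compounds than are shown below. What is called first, only, known or untested is meant among the compounds shown, and "the series" means these compounds.

Measured so far:
compound 1 `CC1=NN(CC(C)C(=N)S)C(=O)CC1` gives 15.6% in a functional assay on the whole organism (stomach) for inhibition, with Rattus norvegicus as the target, at a dose of 100 mg/kg by the intraduodenal route; a higher number here means more inhibition at the dose given (going by the name of the read-out), a lower number less inhibition;
compound 2 `CC1=NN(C(C)CC(=N)S)C(=O)CC1` gives 17.4%;
compound 3 `CC(CC(=N)S)N1N=C(c2ccccc2)CCC1=O` gives 9.2%.

Compound 2 gives the highest of the three numbers, yet compound 1 and compound 3 both lie within the usual scatter of it, so no order among them can be read. Compound 4 `CC1=NN(CCC(=N)S)C(=O)CC1` is not yet measured. It differs from compound 2 by hydrogen in place of methyl on a saturated chain carbon bound to an amide-type nitrogen in a ring and a saturated chain carbon. Within the data shown here, no measured step removes a group at this place; the only step known, a number 8.2 percentage points lower from compound 2 to compound 3 (within the scatter), changes a different position and stays within the scatter, and compound 1 and compound 2, which carry their methyl on different chain carbons, show near-identical values. Compound 4 is therefore expected to show no step beyond the scatter, a number 2.4 percentage points lower from compound 2 to compound 4 (within the scatter), and is estimated at 15%, with a range from 5% to 28%.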

Compound 4, a percentage reported as inhibition, in the whole organism at one dose (the size of the read-out at that dose, not a potency): 34.8%
Beside the measured number, compound 4's estimate is 19.8 percentage points below it; measured number above the stated range.
By their numbers in this assay, from the lowest: compounds 3, 1 and 2 (each within the scatter of the next); then compound 4.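

In this assay, the chain methyl matters at both carbons: hydrogen in its place on a saturated chain carbon bound to an amide-type nitrogen in a ring and a saturated chain carbon gives a number 17.4 percentage points higher from compound 2 to compound 4 (beyond the scatter), and on a saturated chain carbon bound to a carbon with a double bond to nitrogen and a saturated chain carbon it gives a number 19.2 percentage points higher from compound 1 to compound 4 (beyond the scatter). Among these compounds, these are the first steps beyond the scatter, and they set the unbranched chain of compound 4 above both methyl-bearing chains. Nothing in the data shown gives a reason for this.

As far as these compounds go, it remains open whether a longer chain in place of the unbranched one of compound 4 would keep this higher number. From the compounds shown here alone, it is also open whether an ethyl group on either chain carbon would behave as methyl does.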